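Benzyloxy to (3-methylbut-2-en-1-yl)oxy: expectation for compound 4

The source may report more compounds than this note shows. Statements on the series, on what has been measured and on what is new or still open speak of the compounds shown alone.

Of the compounds shown here, three have been measured in a functional assay on PANC-1 cells (Homo sapiens) for inhibition, read by MTT assay, with a stated time of 24 h, tested at 10 uM; a lower number here means less inhibition, a higher number more inhibition at the concentration tested (going by the name of the read-out). Compound 1 `CC(C)=CCC1Cc2c(OCc3ccccc3)cc(=O)n(CCCO)c2CC1(C)C` gives 11.1% in this assay. Compound 2 `CC(C)=CCOc1cc(=O)n(CCCO)c2c1CC(CC=C(C)C)C(C)(C)C2` gives 7.5% in this assay, and compound 3 `CC(C)=CCC/C(C)=C/CC1Cc2c(OCc3ccccc3)cc(=O)n(CCCO)c2CC1(C)C` gives 1.5% in this assay. All three readings sit close together; the step of a number 3.6 percentage points lower from compound 1 to compound 2 (within the scatter) and the step of a number 9.6 percentage points lower from compound 1 to compound 3 (within the scatter) both stay inside the usual scatter, so none of the three can be called apart from the others.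

Compound 4 `CC(C)=CCC/C(C)=C/CC1Cc2c(OCC=C(C)C)cc(=O)n(CCCO)c2CC1(C)C` has not been measured. It differs from compound 3 by 2-methylprop-1-en-1-yl in place of phenyl on a saturated chain carbon bound to an oxygen on an aromatic ring. The same change is found once among the measured compounds, from compound 1 to compound 2, where it reads 2-methylprop-1-en-1-yl in place of phenyl on a saturated chain carbon bound to an oxygen on an aromatic ring and gave a number 3.6 percentage points lower from compound 1 to compound 2 (within the scatter). The place of the change is described in the same words in both pairs, so it is the same change on two cores. The two cores themselves differ by 3-methylbut-2-en-1-yl in place of hydrogen on a saturated chain carbon bound to a double-bonded chain carbon.

Among the compounds with values here, since the one measured example of this change gave only a number 3.6 percentage points lower from compound 1 to compound 2 (within the scatter), the step from compound 3 to compound 4 in this assay is expected to be of similar small size, a number 1.5 percentage points lower from compound 3 to compound 4 (within the scatter), and to stay inside the scatter, with the read-out unable to drop far beneath the reading of compound 3, which is already near the floor. Compound 4 is therefore estimated at 0% in this assay, with a range from -8% to 8%. Within the data shown here, this rests on the single pair of compound 1 and compound 2 alone and carries the uncertainty of one example.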

Compound 4, a percentage reported as inhibition, at one concentration (the size of the read-out at that concentration, not a potency): 15.9%
Beside the measured number, compound 4's estimate is 15.9 percentage points below it; the measured number lies above the stated range.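

In this assay, the change from benzyloxy to (3-methylbut-2-en-1-yl)oxy gives a number 14.4 percentage points higher from compound 3 to compound 4 (beyond the scatter), and its size and direction do not carry over from one core to the other: the same change on two cores in this assay, a number 3.6 percentage points lower (within the scatter) from compound 1 to compound 2 and a number 14.4 percentage points higher (beyond the scatter) from compound 3 to compound 4, 18 percentage points apart, beyond the scatter of two such steps

The second change, 3-methylbut-2-en-1-yl in place of hydrogen on a saturated chain carbon bound to a double-bonded chain carbon, gives a number 8.4 percentage points higher from compound 2 to compound 4 (within the scatter), and its two readings also part: the same change on two cores in this assay, a number 9.6 percentage points lower (within the scatter) from compound 1 to compound 3 and a number 8.4 percentage points higher (within the scatter) from compound 2 to compound 4, 18 percentage points apart, beyond the scatter of two such steps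

Both gaps come from the same set of compounds, so they form a single observation that the two changes do not add up in this series; a step read on one core is therefore a poor guide to the other, but the data give no cause for this and no rule beyond these compounds.

The compounds shown leave open how the reading responds on either core to another group on a saturated chain carbon bound to an oxygen on an aromatic ring, such as an amine, a carboxylic acid or a longer chain. They also leave open whether the reading of compound 4 would hold at other concentrations or times, since a single reading at one concentration is not a potency.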